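Ring Swap on the Sulfonyl Sulfur and Cell Cytotoxicity

The compounds below may be only part of what the source reports. "The series", "measured", "known", "first", "only" and "open" are said of these compounds alone.

Compound 1 `O=C(Nc1ccc(F)c(Cl)c1)c1ccc(F)c(S(=O)(=O)N2CCOC[C@H](O)C2)c1`: in an ADME assay on HepG2 2.2.15 cells (Homo sapiens) for cytotoxicity, read by luminescence, with a stated time of 3 days (on this read-out lower numbers stand for higher toxicity in this test and higher numbers for lower toxicity in this test), compound 1 gives 19000 nM.
Compound 2 `CN1CCCN(S(=O)(=O)c2cc(C(=O)Nc3ccc(F)c(Cl)c3)ccc2F)CC1=O`: in this assay compound 2 gives only a limit, > 100000 nM.

Going by the values given here, compound 1 therefore holds the only actual number in this assay; the other value is a limit, (the limit of > 100000 nM in this assay, at which 1 of the 2 values shown sits). Among the compounds with values here, the single measured step is an at least 5.2-fold higher number from compound 1 to compound 2 (0.72 log units; beyond the scatter), a change at the sulfonyl sulfur that replaced the hydroxylated seven-membered ring with a lactam ring.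

Compound 3 `CC1(O)CCCCN(S(=O)(=O)c2cc(C(=O)Nc3ccc(F)c(Cl)c3)ccc2F)C1` differs from compound 1 in the same place: 3-hydroxy-3-methylazepan-1-yl in place of 6-hydroxy-1,4-oxazepan-4-yl on a sulfonyl sulfur. Unlike compound 2, compound 3 keeps a hydroxyl on a seven-membered ring, so the measured step is only a loose guide, and no shift beyond the scatter is expected. Compound 3 is estimated at 15000 nM, between 5000 nM and 50000 nM, which is an expected step of a 1.3-fold lower number from compound 1 to compound 3 (0.10 log units; within the scatter).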

Compound 3, half-maximal cytotoxic concentration: 10000 nM
Compound 3: middle estimate off by 1.5-fold (0.18 log units), on the high side; measured number inside the range.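

The swap of 6-hydroxy-1,4-oxazepan-4-yl for 3-hydroxy-3-methylazepan-1-yl on the sulfonyl sulfur gives a 1.9-fold lower number from compound 1 to compound 3 (0.28 log units; within the scatter), so in this assay this change of ring leaves the read-out within the scatter. The other comparison, an at least 10-fold lower number from compound 2 to compound 3 (1.00 log units; beyond the scatter), lies beyond the scatter, and among the three compounds it is the lactam-bearing compound 2 that stands apart, while the two hydroxylated rings of compound 1 and compound 3 stay together. Compound 2 holds only a limit, not a number: the limit of > 100000 nM in this assay, at which 1 of the 3 values shown sits.

On these data alone, what remains open is whether the hydroxyl, the lactam carbonyl or some other feature of the ring accounts for this gap, as each swap alters several things at once. A plain azepan-1-yl without the hydroxyl, or a ring bearing a carboxylic acid, would test this position further.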